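A few compounds are considered here, and "the series" means these few. Any claim that something is new, unique, unknown or untested is made for them only; others in the source may bear on it.

Compound 1 `CCCC1C(C(=O)OCc2ccccn2)=C(C)NC2=C1C(=O)CCC2` gives 2.6
Compound 2 `CC1=C(C(=O)OCc2ccccn2)C(c2ccco2)C2=C(CCCC2=O)N1` gives 1.4
Compound 3 `CC1=C(C(=O)OCc2ccccn2)C(c2ccc(C#N)cc2)C2=C(CCCC2=O)N1` gives 1.73

In a physicochemical assay for lipophilicity, measured as octanol-water partition (on this read-out higher numbers stand for higher lipophilicity and lower numbers for lower lipophilicity), compound 3 stands second highest of the three (1.73), above compound 2 and under compound 1. Compound 4 `CC1=C(C(=O)OCc2ccccn2)C(c2ccc(O)cc2)C2=C(CCCC2=O)N1` differs from compound 3 in one place, with hydroxy in place of cyano on an aromatic carbon, para to a large group (hydroxy in place of cyano on an aromatic carbon). Within the data shown here, no measured step exchanges these two groups. The closest evidence comes from exchanges of the whole group on a saturated ring carbon, which gave a number 1.20 log units lower from compound 1 to compound 2 (beyond the scatter) and a number 0.87 log units lower from compound 1 to compound 3 (beyond the scatter) and also a number 0.33 log units higher from compound 2 to compound 3 (beyond the scatter) in the same measurement. The change here is narrower, from 4-cyanophenyl to 4-hydroxyphenyl. Among the measured compounds shown here, the smallest of those steps, the one reaching compound 3 from compound 2 at a number 0.33 log units higher from compound 2 to compound 3 (beyond the scatter) as an upper guide, therefore suggests little movement. The expected result is a number 0.13 log units lower from compound 3 to compound 4 (within the scatter) with no clear shift beyond the scatter anticipated. Compound 4 is estimated at 1.6 with 1.2 to 2.1 as its expected range.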

Compound 4, partition coefficient: 1.58
Estimate against measurement, compound 4: 0.02 log units above, and the stated range covers the measured number.
By their numbers in this assay, from the lowest: compounds 2, 4 and 3 (each within the scatter of the next, the first and the last beyond it); then compound 1.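

In this assay, hydroxy in place of cyano on an aromatic carbon gave a number 0.15 log units lower from compound 3 to compound 4 (within the scatter) and so did not separate these two groups, the first exchange shown at this position on the six-membered aromatic ring. Exchanging the whole group gave a number 0.18 log units higher from compound 2 to compound 4 (within the scatter) for 4-hydroxyphenyl in place of furan-2-yl, while a number 0.33 log units higher from compound 2 to compound 3 (beyond the scatter) is printed for 4-cyanophenyl in the same place, so only the latter group stands clear of furan-2-yl. The replacement of propyl still gave a number 1.02 log units lower from compound 1 to compound 4 (beyond the scatter) and thus compound 1 stays apart from all three other compounds, though no measurement shown accounts for any of these steps.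

The compounds shown leave open where an amine or a methoxy group on the same aromatic carbon would stand. They also leave open where a longer chain in place of propyl would fall.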